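The compounds below may be only part of what the source reports. "The series", "measured", "known", "first", "only" and "open" are said of these compounds alone.

Measured in a functional assay with Homo sapiens as the target; on this read-out higher numbers stand for weaker inhibition and lower numbers for stronger inhibition:

- compound 1 `CC(C)[C@H](NC(=O)COc1cccc2ccccc12)C(=O)N[C@@H](CC(=O)O)C(=O)COc1ccccc1` gives 11200 nM
- compound 2 `CC(C)[C@H](NC(=O)COc1cccc2ccccc12)C(=O)N[C@@H](CC(=O)O)C(=O)COc1cccc2ccccc12` gives 19000 nM
- compound 3 `CC(C)[C@H](NC(=O)COc1cccc2ccccc12)C(=O)N[C@@H](CC(=O)O)C(=O)COc1ccccc1C(F)(F)F` gives 17300 nM

These three compounds share a core and differ only in the aryl group on the oxygen of the phenoxymethyl ketone end. Compound 1 stands within the scatter of both others, and no order can be read among the three values. Compound 4 `CC(C)[C@H](NC(=O)COc1cccc2ccccc12)C(=O)N[C@@H](CC(=O)O)C(=O)COc1ccc(Oc2ccc(C(F)(F)F)cc2)cc1` is compound 1 with one addition to its phenyl: 4-(trifluoromethyl)phenoxy in place of hydrogen on an aromatic carbon. The new group is 4-(trifluoromethyl)phenoxy in place of hydrogen on an aromatic carbon.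

Among the measured compounds shown here, two measured steps bear on this change. Adding trifluoromethyl to the same phenyl gave a 1.5-fold higher number from compound 1 to compound 3 (0.19 log units; within the scatter). Replacing the phenyl with naphthalen-1-yl gave a 1.7-fold higher number from compound 1 to compound 2 (0.23 log units; within the scatter). Both changes add bulk to this end of the molecule, and neither moved the value beyond the scatter. No measured compound carries a second phenyl ring joined through oxygen, and the range is kept wide for that reason.

On this evidence, no step beyond the scatter is expected in this assay. The expected step is a 1.3-fold higher number from compound 1 to compound 4 (0.13 log units; within the scatter). For compound 4 the estimated value is 15000 nM, with an expected range from 6000 nM to 40000 nM.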

Compound 4, half-maximal inhibitory concentration: 24900 nM
Compound 4: middle estimate off by 1.7-fold (0.22 log units), on the low side, within the range that was stated.
By their numbers in this assay, from the lowest: compounds 1, 3, 2 and 4 (each within the scatter of the next, the first and the last beyond it).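

In this assay, among the compounds shown here, a 2.2-fold higher number from compound 1 to compound 4 (0.35 log units; beyond the scatter) is the first change at this end of the molecule to pass beyond the scatter, whereas a 1.5-fold higher number from compound 1 to compound 3 (0.19 log units; within the scatter) and a 1.7-fold higher number from compound 1 to compound 2 (0.23 log units; within the scatter) stayed within it. The separation is modest and holds only against compound 1, as compound 4 remains within the scatter of compound 2, its neighbour in the order of values. The phenyl of compound 1 therefore takes 4-(trifluoromethyl)phenoxy, with its 11 heavy atoms and one further six-membered aromatic ring, at the cost of only a modest rise in the number, and nothing available explains why this group crosses the scatter when the smaller changes did not.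

The compounds shown leave open whether the rise belongs to the outer ring, to the oxygen that joins it or to its trifluoromethyl, a question that plain phenoxy or a methylene link in place of the oxygen could address. They also leave open whether an amine or a carboxylic acid on the outer ring would bring the number down towards or below that of compound 1.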